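A few compounds are considered here, and "the series" means these few. Any claim that something is new, unique, unknown or untested is made for them only; others in the source may bear on it.

In an ADME assay on Vero cells (Chlorocebus sabaeus) for cytotoxicity, read by MTT assay, with a stated time of 72 h (on this read-out lower numbers stand for higher toxicity in this test and higher numbers for lower toxicity in this test), compound 1 `COc1c(N2CCN(CCC#N)C(C)C2)c(F)cc2c(=O)c(C(=O)O)cn(C3CC3)c12` gives 500 ug/mL and compound 2 `COC(=O)CN1CCN(c2c(F)cc3c(=O)c(C(=O)O)cn(C4CC4)c3c2OC)CC1C` gives 500 ug/mL, which is no change at the digits printed from compound 1 to compound 2 (within the scatter). Compound 3 `CO/N=C(\C)CN1CCN(c2c(F)cc3c(=O)c(C(=O)O)cn(C4CC4)c3c2OC)CC1C` stands lowest of the three at 49.6 ug/mL, with a 10-fold lower number from compound 1 to compound 3 (1.00 log units; beyond the scatter) and a 10-fold lower number from compound 2 to compound 3 (1.00 log units; beyond the scatter). Compound 4 `COc1c(N2CCN(C/C(C)=N/NC(N)=O)C(C)C2)c(F)cc2c(=O)c(C(=O)O)cn(C3CC3)c12` differs from compound 3 by ureido in place of methoxy on a double-bonded nitrogen. Going by the values given here, no measured step makes this exchange. The two steps into compound 3 only gauge how far a change on this chain has moved the numbers in this assay. A partial return toward higher numbers is expected, smaller than those steps, and the estimated step is a 2.4-fold higher number from compound 3 to compound 4 (0.38 log units; beyond the scatter). For compound 4 the expected value is 120 ug/mL, with an estimated range of 40 ug/mL to 400 ug/mL.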

Compound 4, half-maximal cytotoxic concentration: 500 ug/mL
Estimate against measurement, compound 4: 4.2-fold (0.62 log units) below; the whole stated range lies below it.
By their numbers in this assay, from the lowest: compound 3; then compounds 1, 2 and 4 (each within the scatter of the next).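

On a double-bonded nitrogen, ureido in place of methoxy gives a 10-fold higher number from compound 3 to compound 4 (1.00 log units; beyond the scatter) in this assay, so the low number of compound 3 does not extend to every group at this place. The remaining steps, no change at the digits printed from compound 2 to compound 4 (within the scatter) and no change at the digits printed from compound 1 to compound 4 (within the scatter), leave compound 3 as the only one of the four that stands apart. No evidence is available on what lies behind this difference. Going by these compounds, whether the low number is specific to methoxy remains open. Hydroxy or ethoxy on the same double-bonded nitrogen would test this.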